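The compounds below may be only part of what the source reports. "The series", "measured", "known", "first", "only" and "open" are said of these compounds alone.

Working notes on the series. In a functional assay on brain (Rattus norvegicus, strain Wistar) for inhibition (a higher number here means a weaker inhibitor, a lower number a stronger inhibitor), compound 1 (`CCCCc1ccc(-c2c(CC)[nH]c(=O)n2C)cc1`) gives 13900 nM and compound 2 (`CCCCOc1ccc(-c2c(C)[nH]c(=O)n2C2CCCCC2)cc1`) gives 13900 nM as well. Compound 3 (`Cc1ccc(-c2c(C)[nH]c(=O)n2C)cc1`) gives 85300 nM, the highest of the three numbers, which makes it the weakest inhibitor of the set, with the other two lower by an amount beyond the scatter.

Compared with compound 3, compound 4 (`Cc1[nH]c(=O)n(C)c1-c1ccc(OCCC(C)C)cc1`) carries isopentyloxy in place of methyl on an aromatic carbon. For the measured compounds named here, no measured pair differs in one place only, so this change has no direct precedent. Compound 1 and compound 2 each differ from compound 3 in more than one place, and neither isolates the change. Even so, the expectation in this assay leans on compound 1 at 13900 nM and compound 2 at 13900 nM, both of which pair a longer group with a lower number than compound 3 shows. A drop beyond the scatter is therefore expected, of about the size of the gap those values leave, though with wide uncertainty. The expected step is a 7.1-fold lower number from compound 3 to compound 4 (0.85 log units; beyond the scatter) in the direction of a stronger inhibitor. For compound 4 the estimate is 12000 nM, with an expected range from 3000 nM to 40000 nM at this stage.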

Compound 4, half-maximal inhibitory concentration: 6600 nM
Estimate against measurement, compound 4: 1.8-fold (0.26 log units) above; the range from low to high includes it.
By their numbers in this assay, from the lowest: compound 4; then compounds 1 and 2 (each within the scatter of the next); then compound 3.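

In this assay, for the compounds shown here, isopentyloxy in place of methyl on an aromatic carbon gives a 13-fold lower number from compound 3 to compound 4 (1.11 log units; beyond the scatter) and so provides the first step that isolates a single place. At this position on the six-membered aromatic ring of carbon only, the larger group, with its 6 heavy atoms against the single carbon of methyl, goes with a stronger inhibitor rather than a weaker one, and the step is large. Compound 1 and compound 2 each differ from compound 3 in more than one place and could not show this for the position on its own, and nothing in the available data accounts for the size of the step.

From the compounds shown here alone, whether the step follows the oxygen or the length of the chain stays open, and methoxy at this place on the shared core, with nothing else changed, would begin to separate the two. Also open, going by these compounds, is how far the trend extends, which a longer chain such as octyloxy, or a chain ending in an amine or a carboxylic acid, would test at the same position.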